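The source may report more compounds than this note shows. Statements on the series, on what has been measured and on what is new or still open speak of the compounds shown alone.

Compound 1 `COc1ccc(C(=O)Nc2ccccc2F)cc1OC1CCCC1`: 10700 nM
Compound 2 `COc1ccc(C(=O)Nc2ccccc2SC)cc1OC1CCCC1`: 1200 nM
Compound 3 `COc1ccc(C(=O)Nc2ccncc2)cc1OC1CCCC1`: 800 nM

In an assay on isolated protein for inhibition of phosphodiesterase 4A (Sus scrofa) (a lower number here means a stronger inhibitor, a higher number a weaker inhibitor), compound 3 holds the lowest of the three numbers, but only the gap to compound 1 is beyond the scatter: a 13-fold lower number from compound 1 to compound 3 (1.13 log units; beyond the scatter), whereas a 1.5-fold lower number from compound 2 to compound 3 (0.18 log units; within the scatter). Compound 4 `COc1ccc(C(=O)Nc2c(C)nsc2C)cc1OC1CCCC1` differs from compound 3 in one place: 3,5-dimethyl-1,2-thiazol-4-yl in place of pyridin-4-yl on an amide-type nitrogen. Of the measured steps, the two that change the group on the amide-type nitrogen bear on this, a 13-fold lower number from compound 1 to compound 3 (1.13 log units; beyond the scatter) and a 1.5-fold lower number from compound 2 to compound 3 (0.18 log units; within the scatter), and they show that such exchanges can move the number a good deal or hardly at all. Among the measured compounds shown here, no measured step exchanges the pyridin-4-yl for a five-membered ring, so the step of a 1.9-fold higher number from compound 3 to compound 4 (0.27 log units; within the scatter) is expected to be modest, more likely toward a higher number. Compound 4 is estimated at 1500 nM, within 300 nM to 7000 nM.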

Compound 4, half-maximal inhibitory concentration: 500 nM
Compound 4: middle estimate off by 3.0-fold (0.48 log units), on the high side; low and high end bracket the measured number.
By their numbers in this assay, from the lowest: compounds 4, 3 and 2 (each within the scatter of the next, the first and the last beyond it); then compound 1.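

In this assay a five-membered ring, 3,5-dimethyl-1,2-thiazol-4-yl, on the amide-type nitrogen matches pyridin-4-yl within the scatter (a 1.6-fold lower number from compound 3 to compound 4 (0.20 log units; within the scatter)), so among these compounds a six-membered ring is not needed at this position. It also separates from both substituted phenyl groups (a 2.4-fold lower number from compound 2 to compound 4 (0.38 log units; beyond the scatter); a 21-fold lower number from compound 1 to compound 4 (1.33 log units; beyond the scatter)), the gap to compound 2 being beyond the scatter, which compound 3 did not achieve. Nothing available explains these steps. As far as these compounds go, whether the two methyl groups matter stays open, as does how an unsubstituted 1,2-thiazol-4-yl, or a ring carrying an amine or a carboxylic acid, would fare on this nitrogen.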